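The source may report more compounds than this note shows. Statements on the series, on what has been measured and on what is new or still open speak of the compounds shown alone.

Measured so far:
compound 1, `CC1=NN(c2ccc(C)cc2)C(=O)C12C=CC(=O)C=C2c1cccc(C)c1`, 8340 nM
compound 2, `CC1=NN(c2ccc(C)cc2)C(=O)C12C=CC(=O)C=C2c1ccc(C)cc1`, 9710 nM
compound 3, `CC1=NN(c2ccc(Cl)cc2)C(=O)C12C=CC(=O)C=C2c1ccc(C)cc1`, 10300 nM

These three values come from a functional assay on HCT-116 cells (Homo sapiens) for antiproliferative activity, read by CCK-8 assay, with a stated time of 72 h (a lower number here means a stronger inhibitor, a higher number a weaker inhibitor), and all three lie close together. Compound 4, `CC1=NN(c2ccc(Cl)cc2)C(=O)C12C=CC(=O)C=C2c1cccc(C)c1`, has not yet been measured in this assay. Compound 4 differs from compound 3 by 3-methylphenyl in place of 4-methylphenyl on a double-bonded ring carbon. The same change separates compound 2 from compound 1, where it gave a 1.2-fold lower number from compound 2 to compound 1 (0.07 log units; within the scatter). The two cores on which this change is made differ by chloro in place of methyl on an aromatic carbon. Since the step from compound 2 to compound 1 stayed within the scatter, the step of a 1.2-fold lower number from compound 3 to compound 4 (0.06 log units; within the scatter) is expected to be of similar small size, resting on a 1.2-fold lower number from compound 2 to compound 1 (0.07 log units; within the scatter). On that basis compound 4 is expected to give about 8900 nM in this assay. The expected range for compound 4 runs from 5500 nM to 14500 nM.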

Compound 4, half-maximal inhibitory concentration: 13300 nM
Beside the measured number, compound 4's estimate is 1.5-fold (0.17 log units) below it; low and high end bracket the measured number.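

In this assay, 3-methylphenyl in place of 4-methylphenyl gave a 1.3-fold higher number from compound 3 to compound 4 (0.11 log units; within the scatter), which does not differ from the same change on the other core: the same change on two cores in this assay, a 1.2-fold lower number (0.07 log units; within the scatter) from compound 2 to compound 1 and a 1.3-fold higher number (0.11 log units; within the scatter) from compound 3 to compound 4, 1.5-fold (0.18 log units) apart, within the scatter of two such steps Chloro in place of methyl gave a 1.6-fold higher number from compound 1 to compound 4 (0.20 log units; within the scatter), and it likewise does not differ between the two cores: the same change on two cores in this assay, a 1.1-fold higher number (0.03 log units; within the scatter) from compound 2 to compound 3 and a 1.6-fold higher number (0.20 log units; within the scatter) from compound 1 to compound 4, 1.5-fold (0.18 log units) apart, within the scatter of two such steps This shows that both changes stayed small on both cores, but with every step within the scatter and only two cores shown, it does not show that a larger effect would carry from one core to another.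

The compounds shown leave open whether a step beyond the scatter can be reached in this series at all. An amine or a carboxylic acid on either phenyl ring, or a longer chain in place of methyl, might answer that.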